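This account rests on a few compounds, and the source may have more. Where it says the series, first, only, none or still open, it means among the compounds named here.

Compounds measured:
compound 1 `COc1ccc(-c2nc(Nc3ccccc3)sc2CC(=O)O)cc1` — 1900 nM
compound 2 `O=C(O)Cc1sc(Cc2ccccc2)nc1-c1ccc(Cl)cc1` — 180 nM
compound 3 `O=C(O)Cc1sc(Cc2ccc(Cl)cc2)nc1-c1ccccc1` — 88 nM

In an in vitro assay on COS-7 cells for displacement of a labelled ligand from prostaglandin D2 receptor 2 (Homo sapiens) (a higher number here means a weaker inhibitor, a lower number a stronger inhibitor), compound 3 gives the lowest number of the three. Compound 2 comes nearest to it, and the gap between the two is beyond the usual scatter; compound 1 stands furthest away, with a much higher number in this assay than compound 3. Within the data shown here, no single-point step between measured compounds is available, so these values are read only as they stand.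

Compound 4 `O=C(O)Cc1sc(Cc2ccc(Cl)cc2)nc1-c1ccc(Cl)cc1` is not yet measured. It differs from compound 3 by chloro in place of hydrogen on an aromatic carbon; cut one bond further out, the change reads phenyl to 4-chlorophenyl. Compound 2 carries the same 4-chlorophenyl on that side of the core, and in this assay compound 2 gives 180 nM against an unsubstituted phenyl there, so the added chloro on the aryl attached to the core is not expected to hurt. A small step to a lower number, or none beyond the scatter, is the expectation for the move from compound 3 to compound 4, of size a 1.5-fold lower number from compound 3 to compound 4 (0.17 log units; within the scatter). Compound 4 is therefore expected to give about 60 nM in this assay, within a range of 25 nM to 150 nM.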

Compound 4, half-maximal inhibitory concentration: 50 nM
Estimate against measurement, compound 4: 1.2-fold (0.08 log units) above; the range from low to high includes it.
By their numbers in this assay, from the lowest: compounds 4 and 3 (each within the scatter of the next); then compound 2; then compound 1.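

In this assay, chloro in place of hydrogen on the aryl attached to the core gives a 1.8-fold lower number from compound 3 to compound 4 (0.25 log units; within the scatter), so at this position the change cannot be told apart from the scatter. Among these compounds, the same change on the aryl held through the methylene link gives a 3.6-fold lower number from compound 2 to compound 4 (0.56 log units; beyond the scatter), a modest step beyond the scatter, which is the first single-place comparison to show a clear drop in the number. No measurement here bears on the reason for either step.

Compound 1 differs from the others in more than one place, so its steps cannot be read. Going by these compounds, whether fluoro or trifluoromethyl in place of chloro on either aryl, or a longer chain in place of the methylene link, would shift the number remains open.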